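Thiadiazole biphenyl amines: side-chain variation in vivo

The source may report more compounds than this note shows. Statements on the series, on what has been measured and on what is new or still open speak of the compounds shown alone.

Measured compounds:
compound 1 `CC(C)NCc1nnc(-c2ccccc2-c2ccccc2)s1` gives 23 mg/kg
compound 2 `c1ccc(CNCc2nnc(-c3ccccc3-c3ccccc3)s2)cc1` gives 37 mg/kg
compound 3 `CC(N)c1nnc(-c2ccccc2-c2ccccc2)s1` gives 21 mg/kg

In a functional assay on the whole organism with Mus musculus as the target (on this read-out lower numbers stand for an effect already at smaller amounts and higher numbers for an effect only at larger amounts of compound), compound 3 stands close to the other two members of the series; the steps of a 1.1-fold lower number from compound 1 to compound 3 (0.04 log units; within the scatter) and a 1.6-fold higher number from compound 1 to compound 2 (0.21 log units; within the scatter) both lie within the scatter, so the three amine side chains on the shared core are so far indistinguishable. Compound 4 `CN(C)Cc1nnc(-c2ccccc2-c2ccccc2)s1` carries (dimethylamino)methyl in place of 1-aminoethyl on an aromatic carbon. Within the data shown here, no measured step covers this exact change, but the two steps known for the series, both within the scatter, suggest that varying the amine side chain has little effect here. Compound 4 is therefore expected to show a 1.2-fold higher number from compound 3 to compound 4 (0.08 log units; within the scatter), no step beyond the scatter. The estimate for compound 4 is 25 mg/kg, with a range from 10 mg/kg to 60 mg/kg.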

Compound 4, dose for half-maximal effect: 32 mg/kg
For compound 4 the middle estimate is 1.3-fold (0.11 log units) below the measured one, within the range that was stated.
By their numbers in this assay, from the lowest: compounds 3, 1, 4 and 2 (each within the scatter of the next).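

In this assay, (dimethylamino)methyl in place of 1-aminoethyl removes the side chain's hydrogen-bond donor and gives a 1.5-fold higher number from compound 3 to compound 4 (0.18 log units; within the scatter), so a donor on this amine is not needed for activity in this range. Dimethylamino on the saturated chain carbon also stays within the scatter of the other two amines: a 1.4-fold higher number from compound 1 to compound 4 (0.14 log units; within the scatter), and a 1.2-fold lower number from compound 2 to compound 4 (0.06 log units; within the scatter). No data are available to explain these small steps.

Open, going by these compounds, is whether a side chain without a basic amine, such as hydroxymethyl or a carboxylic acid, keeps this activity. Also open, on these data alone, is whether a longer chain carrying the amine does.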